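From carbamoyl to sulfamoyl on a double-bonded nitrogen

The source may hold more compounds than are shown below. What is called first, only, known or untested is meant among the compounds shown, and "the series" means these compounds.

Measured so far in a functional assay (aorta) with Rattus norvegicus as the target; a lower number here means that less compound is needed, a higher number that more compound is needed for the effect:
compound 1 `CN(C)/C(=N\C#N)C1=CC(C)(C)Oc2ccc([N+](=O)[O-])cc21` gives > 31600 nM as a limit
compound 2 `CN(C)/C(=C\[N+](=O)[O-])C1=CC(C)(C)Oc2ccc([N+](=O)[O-])cc21` gives 6460 nM as a number
compound 3 `CN(C)/C(=N\C(N)=O)C1=CC(C)(C)Oc2ccc([N+](=O)[O-])cc21` gives > 31600 nM as a limit

For compound 3 the result is a limit: > 31600 nM is all that is known. The next compound to be tested is compound 4 `CN(C)/C(=N\S(N)(=O)=O)C1=CC(C)(C)Oc2ccc([N+](=O)[O-])cc21`, which has sulfamoyl in place of carbamoyl on a double-bonded nitrogen with the shared core unchanged.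

Among the measured compounds shown here, the one measured step at this nitrogen is a step that the two limits leave unreadable from compound 1 to compound 3 and it gives no size to carry over. The most common result in the series is the limit of > 31600 nM in this assay, at which 2 of the 3 values shown sit, and it points to another limit. Compound 2 goes against that pattern and gives 6460 nM as a measured number on the shared core. For the measured compounds named here, no measured step connects it to the sulfamoyl change.

No clear shift in this assay is therefore expected, and any readable change could only be towards a lower number. The expected size is an at least 1.2-fold lower number from compound 3 to compound 4 (0.10 log units; that floor lies within the scatter) and a further limit is about as likely as a number. For compound 4 the estimate is 25000 nM with an expected range from 5000 nM to 80000 nM in this reading.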

Compound 4, half-maximal effective concentration: > 31600 nM
Compound 4 ended at the assay's limit; the forecaster's own chance of this, stated with the estimate: 55%; at least 1.2-fold (0.10 log units) between middle value and limit.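

In this assay compound 4 gives > 31600 nM, which is a limit. No new step can be read, as the values of compound 1, compound 3 and compound 4 are all limits, and the series' most common result is unchanged: the limit of > 31600 nM in this assay, at which 3 of the 4 values shown sit.

Going by these compounds, whether cyano, carbamoyl and sulfamoyl on a double-bonded nitrogen differ at all in this assay remains open.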